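This account rests on a few compounds, and the source may have more. Where it says the series, first, only, none or still open, it means among the compounds named here.

Compound 1 `FC(F)(F)c1ccc(Nc2cccc3sc(Nc4c(Cl)cccc4Cl)nc23)cc1`: in a functional assay on HEK293 cells for antagonist activity at transient receptor potential cation channel subfamily V member 1 (Homo sapiens), read by calcium flux (on this read-out lower numbers stand for stronger inhibition and higher numbers for weaker inhibition), compound 1 gives > 5000 nM, which is a limit of the assay and not a number.
Compound 2 `FC(F)(F)c1ccc(Nc2ncnc3sc(Nc4ccccc4Cl)nc23)cc1`: in this assay compound 2 gives 64 nM.

Among the measured compounds shown here, compound 2 carries the only numeric result so far; the other entry sits at the limit of > 5000 nM in this assay, at which 1 of the 2 values shown sits, so no measured step is available and compound 2 cannot be ranked against anything.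

Compound 3 `N#Cc1cc(Cl)c(Nc2nc3c(Nc4ccc(C(F)(F)F)cc4)ncnc3s2)c(Cl)c1` is the next candidate. It differs from compound 2 by 2,6-dichloro-4-cyanophenyl in place of 2-chlorophenyl on a nitrogen on an aromatic ring whose other neighbours are aromatic carbon. For the measured compounds named here, no measured pair isolates this change, so its effect is unknown. The expected step is a 1.1-fold higher number from compound 2 to compound 3 (0.04 log units; within the scatter), a change not beyond the usual scatter in either direction. Compound 3 is therefore estimated at 70 nM in this assay, with a range from 20 nM to 300 nM.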

Compound 3, half-maximal inhibitory concentration: 95 nM
Beside the measured number, compound 3's estimate is 1.4-fold (0.13 log units) below it; the measured number falls inside the stated range.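

The group on a nitrogen on an aromatic ring now has its first measured step: 2,6-dichloro-4-cyanophenyl in place of 2-chlorophenyl gives a 1.5-fold higher number from compound 2 to compound 3 (0.17 log units; within the scatter) in this assay for this change. The position therefore carries either group, one of them with a nitrile and a second chlorine, with no difference that this read-out separates from scatter. Among the compounds shown here, nothing measured so far gives a reason for the size of this step.

As far as these compounds go, the step changes the second chlorine and the nitrile together, so the share of each stays open, and a phenyl ring with only the nitrile would be needed to separate them. The compounds shown also leave open how a saturated group on this nitrogen, such as cyclohexyl or morpholine, would read out.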